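Swapping a Benzyl Group for tert-Butyl on the Core

This account rests on a few compounds, and the source may have more. Where it says the series, first, only, none or still open, it means among the compounds named here.

Measured so far:
- compound 1, `Cc1cccc(Cc2cnc(CCc3ccc(-c4ccccc4C(=O)O)cc3)[nH]2)c1`: 4310 nM
- compound 2, `CCCCc1cnc(C(CC)Cc2ccc(-c3ccccc3C(=O)O)cc2)[nH]1`: 2720 nM

In an in vitro functional assay on cells for agonist activity at Bombesin receptor subtype-3 (Homo sapiens), read by luminescence and calcium flux (on this read-out higher numbers stand for an effect only at larger amounts of compound and lower numbers for an effect already at smaller amounts), compound 1 gives 4310 nM, and compound 2 gives 2720 nM; these two numbers lie within the usual scatter of each other, so compound 1 cannot be set apart from compound 2. Compound 3, `CC(C)(C)c1cnc(CCc2ccc(-c3ccccc3C(=O)O)cc2)[nH]1`, has not yet been measured. It differs from compound 1 in one place: tert-butyl in place of 3-methylbenzyl on an aromatic carbon. Within the data shown here, nothing measured so far isolates this change, so the step of a 1.2-fold lower number from compound 1 to compound 3 (0.09 log units; within the scatter) is expected to be small, not beyond the scatter. Compound 3 is therefore estimated at 3500 nM, between 1200 nM and 10000 nM.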

Compound 3, half-maximal effective concentration: 4330 nM
For compound 3 the middle estimate is 1.2-fold (0.09 log units) below the measured one; the range from low to high includes it.
By their numbers in this assay, from the lowest: compounds 2, 1 and 3 (each within the scatter of the next).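

Among these compounds, putting tert-butyl in place of 3-methylbenzyl on this aromatic carbon gives a 1.0-fold higher number from compound 1 to compound 3 (0.00 log units; within the scatter) in this assay and is the first direct test of this position. The group's six-membered aromatic ring can go and its heavy atoms can fall from 8 to 4 without the number leaving the scatter. At this position, then, the benzene ring of 3-methylbenzyl is not needed for the activity seen in these two compounds.

From the compounds shown here alone, whether an amine or a carboxylic acid here would leave the number as unchanged remains open. Among the compounds shown here, nothing measured so far explains why this exchange leaves the value in place.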